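Methyl in Place of Chloro on the Aryl of Compound 3

The source may report more compounds than this note shows. Statements on the series, on what has been measured and on what is new or still open speak of the compounds shown alone.

Of the compounds shown here, three have been measured in a functional assay on CHO cells for antagonist activity at metabotropic glutamate receptor 1 (Homo sapiens), read by FLIPR; a lower number here means a stronger inhibitor, a higher number a weaker inhibitor. Compound 1 `Cc1ccc(-n2cnc3c(sc4ncc5sc(=S)[nH]c5c43)c2=O)cc1` gives 541 nM in this assay. Compound 2 `O=c1c2sc3ncc4cn[nH]c4c3c2ncn1-c1ccc(Cl)cc1`, built on a different core, gives 37.6 nM. Compound 3 `O=c1c2sc3ncc4cc[nH]c4c3c2ncn1-c1ccc(Cl)cc1` gives 0.4 nM, the lowest of the three numbers, and both the gap to compound 2 and the wider gap to compound 1 lie beyond the usual scatter. Each of these three differs from the others in more than one place, so no single-point step can be read among them.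

Compound 4 `Cc1ccc(-n2cnc3c(sc4ncc5cc[nH]c5c43)c2=O)cc1` has not yet been measured. It arises from compound 3 by one change: methyl in place of chloro on an aromatic carbon. The same difference, cut one bond further out, reads 4-chlorophenyl to 4-methylphenyl. Within the data shown here, no measured pair shows this exchange on a shared core, and compound 1, which carries the 4-methylphenyl on another core, offers no comparable step. The change is expected to shift the number only a little, most likely within the scatter or a modest rise toward weaker inhibition. The estimated step is a 3.0-fold higher number from compound 3 to compound 4 (0.48 log units; beyond the scatter). Compound 4 is therefore expected to give about 1.2 nM, with a range from 0.25 nM to 6 nM.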

Compound 4, half-maximal inhibitory concentration: 0.7 nM
Beside the measured number, compound 4's estimate is 1.7-fold (0.23 log units) above it; the measured number falls inside the stated range.
By their numbers in this assay, from the lowest: compounds 3 and 4 (each within the scatter of the next); then compound 2; then compound 1.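

Among these compounds, replacing 4-chlorophenyl with 4-methylphenyl gives the first single-point step in this assay, a 1.8-fold higher number from compound 3 to compound 4 (0.24 log units; within the scatter), so on the shared core this exchange, made on an aromatic carbon para to a large group, leaves no difference that can be told from the scatter. Among the compounds shown here, the earlier compounds could not show this, since the only compound then carrying the 4-methylphenyl had another core; now compound 4, with 0.7 nM in this assay, shows that the 4-methylphenyl can stand on this core with a number as low as that of the chloro compound. The data hold nothing that explains why chloro and methyl read alike here.

From the compounds shown here alone, the step covers only these two groups, so it remains open how the same place would respond to a methoxy, a trifluoromethyl, a dimethylamino group, a carboxylic acid or a longer chain such as tert-butyl, or to plain hydrogen. It also remains open whether chloro and methyl would read alike on the core of compound 1 or the core of compound 2, each of which is shown with only one of the two groups.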